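Swapping the amide side chain on the core of compound 1

The source may report more compounds than this note shows. Statements on the series, on what has been measured and on what is new or still open speak of the compounds shown alone.

Three compounds have been run in an ADME assay on MDCK-MDR1 cells (Canis lupus familiaris) for permeability, in the apical to basolateral direction, with a stated time of 180 min; a higher number here means that the compound crosses the layer faster, a lower number that the compound crosses the layer more slowly. Compound 1 `CN(C)CCC(=O)Nc1ccc([C@H]2[C@@H](F)[C@@H](F)C[C@@H](F)[C@H]2F)cc1` gives 3.7 10^-6 cm/s, the lowest of the three numbers. Compound 2 `O=C(NCc1cc[nH]n1)c1ccc(C2CCCCC2)cc1` gives 16.7 10^-6 cm/s, and compound 3 `N#CCC(=O)Nc1ccc(C2CCCCC2)cc1` gives 18.6 10^-6 cm/s; both stand beyond the scatter above compound 1, compound 2 being the nearer of the two. No pair among these three differs in one place only, so no single step has been measured in this assay.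

Compound 4 `N#CCC(=O)Nc1ccc([C@H]2[C@@H](F)[C@@H](F)C[C@@H](F)[C@H]2F)cc1` is the next to be measured in this assay. It keeps the core of compound 1 and differs from it in one place: cyano in place of (dimethylamino)methyl on a saturated chain carbon bound to a carbonyl carbon. Compound 3 carries the same ((cyanomethyl)carbonyl)amino group on a different core and gives 18.6 10^-6 cm/s in this assay. Compound 2, with neither side chain, also sits well above compound 1.

The step of a 2.7-fold higher number from compound 1 to compound 4 (0.43 log units; beyond the scatter) is expected to be upward and beyond the scatter. The expectation for compound 4 in this assay is about 10 10^-6 cm/s, with a range from 4 10^-6 cm/s to 22 10^-6 cm/s.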

Compound 4, apparent permeability: 16 10^-6 cm/s
Compound 4: the middle estimate sits 1.6-fold (0.20 log units) below what was measured; the range from low to high includes it.
By their numbers in this assay, from the lowest: compound 1; then compounds 4, 2 and 3 (each within the scatter of the next).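

In this assay, among the compounds shown here, cyano in place of (dimethylamino)methyl on a saturated chain carbon bound to a carbonyl carbon gives a 4.3-fold higher number from compound 1 to compound 4 (0.64 log units; beyond the scatter), the first single change that can be read. The side chain at this place on the core of compound 1 therefore moves the number beyond the scatter, so the low value of compound 1 cannot be assigned to that core alone. No measurement shown explains why the number moves with this change.

The compounds shown do not separate the loss of the dimethylamino nitrogen from the shortening of the chain, since this one change does both. As far as these compounds go, it also remains open how a longer chain ending in a nitrile, a morpholine or a carboxylic acid would read at this place.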